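Series notes: thiazole sulfonamide replacing the aminophenyl of compound 1

The compounds below may be only part of what the source reports. "The series", "measured", "known", "first", "only" and "open" are said of these compounds alone.

Within the data shown here, compound 1 `CC1CCN(C2CCN(S(=O)(=O)c3cccc(N)c3)CC2)CC1` is the weakest of the three measured members: in a functional assay on DLD-1 cells (Homo sapiens) for antiproliferative activity, read by CellTiter-Glo, with a stated time of 72 h (on this read-out higher numbers stand for weaker inhibition and lower numbers for stronger inhibition), compound 1 gives 3400 nM. The two biaryl analogues sit far below it. Compound 2 `COc1ccc(-c2cccc(S(=O)(=O)N3CCC(N4CCC(C)CC4)CC3)c2)cc1` gives 23 nM and compound 3 `CC1CCN(C2CCN(S(=O)(=O)c3cccc(-c4ccc(F)cc4)c3)CC2)CC1` gives 12 nM; the steps of a 150-fold lower number from compound 1 to compound 2 (2.17 log units; beyond the scatter) and a 280-fold lower number from compound 1 to compound 3 (2.45 log units; beyond the scatter) are both large, while a 1.9-fold lower number from compound 2 to compound 3 (0.28 log units; within the scatter) stays within the scatter.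

Compound 4 `Cc1nc(Cl)sc1S(=O)(=O)N1CCC(N2CCC(C)CC2)CC1` changes the sulfonyl-bound ring itself: 2-chloro-4-methyl-1,3-thiazol-5-yl in place of 3-aminophenyl on a sulfonyl sulfur. Among the measured compounds shown here, no measured step shows this kind of exchange. The measured steps only show that adding a 4-methoxyphenyl or a 4-fluorophenyl to the ring of compound 1 lowers the number sharply; compound 4 carries neither, and the entering group has no such second ring. The step from compound 1 to compound 4 is therefore expected to be smaller than either measured step, most likely a modest lowering of the number, with no change beyond the scatter also possible. The estimate for compound 4 in this assay is 1500 nM, between 300 nM and 6000 nM, corresponding to an expected step of a 2.3-fold lower number from compound 1 to compound 4 (0.36 log units; beyond the scatter).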

Compound 4, half-maximal inhibitory concentration: 1.6 nM
Compound 4: middle estimate off by 940-fold (2.97 log units), on the high side; measured number outside the range, below it.
By their numbers in this assay, from the lowest: compound 4; then compounds 3 and 2 (each within the scatter of the next); then compound 1.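

In this assay the exchange of 3-aminophenyl for 2-chloro-4-methyl-1,3-thiazol-5-yl on the sulfonyl sulfur gives a 2100-fold lower number from compound 1 to compound 4 (3.33 log units; beyond the scatter) and so shows that the ring bound directly to the sulfonyl sulfur can by itself carry a large step. The earlier compounds shown here showed large steps only where a 4-methoxyphenyl or a 4-fluorophenyl took the place of the amino group, whereas here a large step appears with neither group present and with no rise in the heavy-atom count of the group on the sulfonyl sulfur. Nothing measured on this series speaks to the cause of the step.

Open, on these data alone, is whether the step follows the chloro, the methyl, the loss of the amino group or the thiazole ring itself, as compound 4 holds all of these changes together. A plain 1,3-thiazol-5-yl, a 2-bromo-4-methyl-1,3-thiazol-5-yl or a 3-chloro-4-methylphenyl on the sulfonyl sulfur would bear on that question, each with the rest of the structure of compound 4 unchanged.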